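Swapping Hydroxycarbamoyl for a Triazole Ring

The source may hold more compounds than are shown below. What is called first, only, known or untested is meant among the compounds shown, and "the series" means these compounds.

Three compounds share one core and differ only in the group attached to a saturated chain carbon bound to a sulfur. Compound 3 `N#Cc1c(N)nc(SCC(=O)NO)c(C#N)c1-c1ccc(OCC2CC2)cc1` carries a hydroxycarbamoyl group there; in an assay on CHO cells for displacement of a labelled ligand from adenosine receptor A3 (Homo sapiens), read by scintillation counting, with a stated time of 120 min, tested at 1 uM (on this read-out lower numbers stand for less inhibition and higher numbers for more inhibition at the one concentration tested (going by the name of the read-out)), compound 3 gives 31%, the highest of the three numbers. Compound 1 `N#Cc1c(N)nc(SCC(=O)NCO)c(C#N)c1-c1ccc(OCC2CC2)cc1` gives 8% in this assay, and compound 2 `N#Cc1c(N)nc(SCc2nnn[nH]2)c(C#N)c1-c1ccc(OCC2CC2)cc1`, bearing a 1H-tetrazol-5-yl group, gives 1%. The step of a number 30 percentage points higher from compound 2 to compound 3 (beyond the scatter) and the step of a number 23 percentage points higher from compound 1 to compound 3 (beyond the scatter) are both beyond the scatter, so compound 3 stands clearly apart from the other two.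

Compound 4 `N#Cc1c(N)nc(SCc2ncn[nH]2)c(C#N)c1-c1ccc(OCC2CC2)cc1` has not yet been measured. Its difference from compound 3 is 1H-1,2,4-triazol-5-yl in place of hydroxycarbamoyl on a saturated chain carbon bound to a sulfur. The measured step that bears most on it is a number 30 percentage points higher from compound 2 to compound 3 (beyond the scatter), in which a five-membered aromatic ring with hetero atoms gave way to hydroxycarbamoyl; compound 4 undoes that kind of change with a ring of the same sort. The step of a number 7 percentage points lower from compound 1 to compound 2 (within the scatter) stayed within the scatter. A drop beyond the scatter is therefore expected, a number 26 percentage points lower from compound 3 to compound 4 (beyond the scatter). Compound 4 is expected to give 5% in this assay, within a range from 0% to 20%.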

Compound 4, a percentage reported as inhibition, at one concentration (the size of the read-out at that concentration, not a potency): 1%
The estimate for compound 4 lay 4 percentage points above the measured number, and the stated range covers the measured number.
By their numbers in this assay, from the lowest: compounds 2, 4 and 1 (each within the scatter of the next); then compound 3.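

Replacing hydroxycarbamoyl with 1H-1,2,4-triazol-5-yl on the saturated chain carbon bound to a sulfur gives a number 30 percentage points lower from compound 3 to compound 4 (beyond the scatter) in this assay, so the low number seen with the 1H-tetrazol-5-yl group is not tied to that one ring. For the compounds shown here, exchanging one ring for the other gives no change at the digits printed from compound 2 to compound 4 (within the scatter), and the step from (hydroxymethyl)carbamoyl to the triazole is a number 7 percentage points lower from compound 1 to compound 4 (within the scatter), which leaves hydroxycarbamoyl as the only one of these four groups clearly apart from the rest. Nothing available explains why this group stands apart.

Going by these compounds, it remains open whether a carboxylic acid or an amine on the same chain carbon would sit with compound 3 or with the other three compounds. On these data alone, a percentage at one concentration is also not a potency, so the true strength of compound 3 at this receptor stays unknown.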